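The compounds below may be only part of what the source reports. "The series", "measured", "known", "first", "only" and "open" are said of these compounds alone.

Going by the values given here, in a physicochemical assay, read by spectrophotometry, with a stated time of 30 min (a higher number here means a weaker inhibitor, a lower number a stronger inhibitor), compound 1 `O=C(CC(c1ccc(F)cc1)c1c[nH]c2ccccc12)c1c(O)c2ccccc2oc1=O` gives 47.4 ug/mL and compound 2 `COc1ccc(OC)c(C(CC(=O)c2c(O)c3ccccc3oc2=O)c2c[nH]c3ccccc23)c1` gives 19 ug/mL as the lower of the two numbers so far. Among the compounds with values here, the single measured step of a 2.5-fold lower number from compound 1 to compound 2 (0.40 log units; beyond the scatter) is modest but beyond the scatter. Next is compound 3 `COc1ccc(C(CC(=O)c2c(O)c3ccccc3oc2=O)c2c[nH]c3ccccc23)cc1OC` with the change 3,4-dimethoxyphenyl in place of 2,5-dimethoxyphenyl on a saturated chain carbon bound to an aromatic carbon and a saturated chain carbon in which 3,4-dimethoxyphenyl takes the place of 2,5-dimethoxyphenyl on a saturated chain carbon bound to an aromatic carbon and a saturated chain carbon. Within the data shown here, no measured pair compares two dimethoxyphenyl groups, so the step of a 2.5-fold lower number from compound 1 to compound 2 (0.40 log units; beyond the scatter) gives only a rough size. A step no larger than that one is expected in this assay and it most likely stays within the scatter, leaning towards a higher number. The estimated step of a 1.5-fold higher number from compound 2 to compound 3 (0.17 log units; within the scatter) reflects this. For compound 3 the estimated value is 28 ug/mL with an expected range from 12 ug/mL to 60 ug/mL on this read-out.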

Compound 3, half-maximal inhibitory concentration: 63.2 ug/mL
Compound 3: the middle estimate sits 2.3-fold (0.35 log units) below what was measured, outside the stated range (above it).
By their numbers in this assay, from the lowest: compound 2; then compounds 1 and 3 (each within the scatter of the next).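

In this assay, 3,4-dimethoxyphenyl in place of 2,5-dimethoxyphenyl on the saturated chain carbon gives a 3.3-fold higher number from compound 2 to compound 3 (0.52 log units; beyond the scatter), and as the two groups hold the same atoms, the read-out at this place distinguishes between two arrangements of one composition. Two methoxy groups alone do not set compound 2 apart: 3,4-dimethoxyphenyl in place of 4-fluorophenyl gives a 1.3-fold higher number from compound 1 to compound 3 (0.12 log units; within the scatter), so among these three compounds only the 2,5-dimethoxyphenyl group gives a number clearly lower than the others. Nothing at hand accounts for the gap between the two dimethoxyphenyl arrangements.

Still open is which of the two methoxy groups of 2,5-dimethoxyphenyl matters, as no compound shown carries a phenyl with a single methoxy group. Also open, on these data alone, is how a hydroxyl or an amine on that phenyl ring would read in this assay, and whether 2,5-dimethoxyphenyl keeps its lower number on a longer chain.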